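A Methyl on the Amine Nitrogen, Tried on a Second Core

The source may report more compounds than this note shows. Statements on the series, on what has been measured and on what is new or still open speak of the compounds shown alone.

Measured so far:
compound 1, `COc1ccc(C(=O)c2ccc(OC)c3c2OC(C)(C)C=C3)c(NC(=O)CN)c1`, 410 nM
compound 2, `COc1ccc(C(=O)c2ccc3c(c2)C=CC(C)(C)O3)c(NC(=O)CN)c1`, 580 nM
compound 3, `CNCC(=O)Nc1cc(OC)ccc1C(=O)c1ccc(OC)c2c1OC(C)(C)C=C2`, 870 nM

All three were run in a functional assay on HeLa cells (Homo sapiens) for antiproliferative activity, read by MTT assay, with a stated time of 48 h; a higher number here means a weaker inhibitor, a lower number a stronger inhibitor. Compound 1 and compound 3 share one core; compound 3 differs from compound 1 by methyl in place of hydrogen on an amine nitrogen, and that change made a 2.1-fold higher number from compound 1 to compound 3 (0.33 log units; beyond the scatter). Compound 2 has another core; how the two cores differ is not broken down here. Compound 2 and compound 1 give numbers within the usual scatter of each other, as do compound 2 and compound 3.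

Compound 4, `CNCC(=O)Nc1cc(OC)ccc1C(=O)c1ccc2c(c1)C=CC(C)(C)O2`, is not yet measured. It differs from compound 2 by methyl in place of hydrogen on an amine nitrogen, the same change as from compound 1 to compound 3, at a place described in the same words. Compound 4 is expected to show a 2.1-fold higher number from compound 2 to compound 4 (0.32 log units; beyond the scatter). That expectation rests on compound 2 giving 580 nM and on the earlier step, a 2.1-fold higher number from compound 1 to compound 3 (0.33 log units; beyond the scatter). Compound 4 is therefore estimated at 1200 nM, likely between 600 nM and 2500 nM.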

Compound 4, half-maximal inhibitory concentration: 970 nM
Compound 4: middle estimate off by 1.2-fold (0.09 log units), on the high side, within the range that was stated.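

On the second core, in this assay, methyl in place of hydrogen on an amine nitrogen gave a 1.7-fold higher number from compound 2 to compound 4 (0.22 log units; within the scatter), so this step alone cannot be told apart from repeat measurement. Set beside the step on the other core, the two agree: the same change on two cores in this assay, a 2.1-fold higher number (0.33 log units; beyond the scatter) from compound 1 to compound 3 and a 1.7-fold higher number (0.22 log units; within the scatter) from compound 2 to compound 4, 1.3-fold (0.10 log units) apart, within the scatter of two such steps. The size of the step thus carried over as far as the scatter can tell, but this rests on a single pair per core and does not show a real loss on the second core taken alone.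

The compounds shown leave open how ethyl or a dimethylamino group would behave at that nitrogen. They also leave open whether a longer chain in place of the aminomethyl would follow the same course, and whether the step holds on any further core.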